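This account rests on a few compounds, and the source may have more. Where it says the series, first, only, none or still open, it means among the compounds named here.

Measured so far:
Compound 1 `N#Cc1ccc(N2CCCc3c(-c4cccnc4)cccc32)cc1C(F)(F)F` gives 13500 nM in a functional assay on VCaP cells (Homo sapiens) for antiproliferative activity, read by CCK-8 assay, with a stated time of 6 days; on this read-out lower numbers stand for stronger inhibition and higher numbers for weaker inhibition.
Compound 2 `CCN(c1ccc(C#N)c(Cl)c1)c1cc(-c2cccs2)ccc1C` has "not determined" (no result reported) in this assay.
Compound 3 `N#Cc1ccc(N2CCCc3c(-c4ccncc4)cccc32)cc1C(F)(F)F` in this assay is reported only as a limit, > 30000 nM.

Compound 2 therefore stands nowhere on the numbers shown; no value for it is reported. Compound 4 `CCN(c1ccc(C#N)c(Cl)c1)c1cc(-n2ccnc2)ccc1C` differs from compound 2 by 1H-imidazol-1-yl in place of thiophen-2-yl on an aromatic carbon. Within the data shown here, the single measured step, an at least 2.2-fold higher number from compound 1 to compound 3 (0.34 log units; beyond the scatter), concerns another change on another core and does not bear on this one; the limit of > 30000 nM in this assay, at which 1 of the 3 values shown sits, marks where the measured values stop. No step size can be expected in this assay in either direction from compound 2, and the estimate rests on the weak level of the whole set. Compound 4 is estimated at 12000 nM, ranging from 2500 nM to 30000 nM, with a real chance that only a limit is returned.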

Compound 4, half-maximal inhibitory concentration: > 30000 nM
Compound 4: only a limit was reported (the forecaster's own chance of this, stated with the estimate: 40%); at least 2.5-fold (0.39 log units) between middle value and limit.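

Compound 4 returns only a limit, > 30000 nM, and with no number for compound 2, no step can be read between compound 2 and compound 4. Going by these compounds, what 1H-imidazol-1-yl in place of thiophen-2-yl does to the read-out stays open.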